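Cyclopropyl for Methoxyphenyl on the Ring Amide Nitrogen

The compounds below may be only part of what the source reports. "The series", "measured", "known", "first", "only" and "open" are said of these compounds alone.

Measured compounds:
compound 1 `COc1cccc(N2C(=O)COc3ccc(-c4cnc(Cl)c(NS(=O)(=O)c5ccc(F)cc5)c4)cc32)c1`: > 40000 nM
compound 2 `COc1ncc(-c2ccc3c(c2)N(c2ccccc2)C(=O)CO3)cc1NS(=O)(=O)c1ccc(F)cc1`: 15200 nM
compound 3 `COc1ccc(N2C(=O)COc3ccc(-c4cnc5ccccc5c4)cc32)cc1`: > 40000 nM

In a functional assay on A-375 cells (Homo sapiens) for antiproliferative activity, read by MTT assay, with a stated time of 72 h (on this read-out higher numbers stand for weaker inhibition and lower numbers for stronger inhibition), compound 1 gives only a limit, > 40000 nM. Compound 3 likewise gives only a limit in this assay, > 40000 nM. Among the measured compounds shown here, compound 2 is the one compound with a number in this assay, 15200 nM. The two limits are the limit of > 40000 nM in this assay, at which 2 of the 3 values shown sit, so compound 1 stands at the weak end of what is known, with no number of its own.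

Compound 4 `O=C1COc2ccc(-c3cnc(Cl)c(NS(=O)(=O)c4ccc(F)cc4)c3)cc2N1C1CC1` is not yet measured. It differs from compound 1 by cyclopropyl in place of 3-methoxyphenyl on an amide-type nitrogen in a ring. For the measured compounds named here, no measured pair differs in one place, so no step size is known here. The step from compound 1 to compound 4 in this assay is expected to be an at least 1.6-fold lower number from compound 1 to compound 4 (0.20 log units; that floor lies within the scatter), not clearly beyond the scatter. The value of compound 4 in this assay is estimated at 25000 nM, between 6000 nM and 40000 nM, with a real chance that only a limit is reported.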

Compound 4, half-maximal inhibitory concentration: 21800 nM
The estimate for compound 4 lay 1.1-fold (0.06 log units) above the measured number; low and high end bracket the measured number.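

In this assay compound 4 gives 21800 nM, so the 3-methoxyphenyl is not needed on the ring amide nitrogen for a measurable value, and the much smaller cyclopropyl is accepted there. The change gives an at least 1.8-fold lower number from compound 1 to compound 4 (0.26 log units; that floor lies within the scatter). Compound 1 gives only a limit, > 40000 nM, so the step has a floor and no fixed size: the limit of > 40000 nM in this assay, at which 2 of the 4 values shown sit.

Still open, on these data alone, is how an open-chain group such as methyl or isopropyl, or a chain ending in an amine, would read on this nitrogen. Also open, as far as these compounds go, is whether the same change carries over to the core of compound 2.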